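The source may report more compounds than this note shows. Statements on the series, on what has been measured and on what is new or still open speak of the compounds shown alone.

For the measured compounds named here, in a functional assay for agonist activity at sphingosine 1-phosphate receptor 5 (Homo sapiens) (on this read-out lower numbers stand for an effect already at smaller amounts and higher numbers for an effect only at larger amounts of compound), compound 3 `C/N=C1\S/C(=C\c2cc(C)n(Cc3ccccc3)c2C)C(=O)N1C` gives 144 nM, the second highest of the three numbers measured so far. Compound 1 `C/N=C1\S/C(=C\c2cc(C)n(Cc3ccccc3F)c2C)C(=O)N1C` gives 51 nM, and compound 2 `C/N=C1\S/C(=C\c2cc(C)n(-c3ccc(F)cc3)c2C)C(=O)N1C` gives 652 nM. Compound 4 `C/N=C1\S/C(=C\c2cc(C)n(-c3ccc(Cl)cc3F)c2C)C(=O)N1C` has not yet been measured; it differs from compound 3 by 4-chloro-2-fluorophenyl in place of benzyl on an aromatic nitrogen. Going by the values given here, two measured steps bear on this change. The step of a 4.5-fold lower number from compound 2 to compound 3 (0.66 log units; beyond the scatter) shows that a benzyl on the aromatic nitrogen gave a lower number than a 4-fluorophenyl there, and the step of a 13-fold higher number from compound 1 to compound 2 (1.11 log units; beyond the scatter) shows a large rise when a 4-fluorophenyl replaced 2-fluorobenzyl. Because a 4.5-fold lower number from compound 2 to compound 3 (0.66 log units; beyond the scatter) runs opposite to the change now made, a rise of similar size is expected, a 3.5-fold higher number from compound 3 to compound 4 (0.54 log units; beyond the scatter). Compound 4 is therefore estimated at 500 nM, with a range from 150 nM to 1800 nM.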

Compound 4, half-maximal effective concentration: 3400 nM
Compound 4: middle estimate off by 6.8-fold (0.83 log units), on the low side, outside the stated range (above it).
By their numbers in this assay, from the lowest: compound 1; then compound 3; then compound 2; then compound 4.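

In this assay, the aromatic nitrogen responds to more than the choice between a benzyl and a directly attached phenyl ring: with the ring directly attached in both compounds, the number still rises, a 5.2-fold higher number from compound 2 to compound 4 (0.72 log units; beyond the scatter). Against the benzyl groups the rise is larger, a 24-fold higher number from compound 3 to compound 4 (1.37 log units; beyond the scatter) and a 67-fold higher number from compound 1 to compound 4 (1.82 log units; beyond the scatter). Nothing measured here says why 4-chloro-2-fluorophenyl gives these rises. The compounds shown do not separate the part played by the chloro from that of the added fluoro. Also open, going by these compounds, is how a longer chain on the aromatic nitrogen, or an amine on its ring, would behave.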